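The source may hold more compounds than are shown below. What is called first, only, known or untested is meant among the compounds shown, and "the series" means these compounds.

Three compounds of this series have numbers in an assay on isolated protein for inhibition of protein deacetylase HDAC6 (Homo sapiens), read by fluorescence, with stated times of 15 min and 30 min; on this read-out higher numbers stand for weaker inhibition and lower numbers for stronger inhibition. Compound 1 `CC(c1ccc(C(=O)NO)cc1)n1[se]c2ccccc2c1=O` gives 863 nM in this assay. Compound 2 `O=C(NO)c1cnc(N2CCC(Cn3[se]c4ccccc4c3=O)CC2)nc1` gives 444 nM in this assay. Compound 3 `O=C(NO)c1ccc(Cn2[se]c3ccc(F)cc3c2=O)cc1` gives 178 nM in this assay, the lowest of the three; its gaps to compound 2 and to compound 1 both lie beyond the scatter, so compound 3 stands as the strongest inhibitor among those measured so far.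

Compound 4 `O=C(NO)c1ccc(Cn2[se]c3ccc(C(F)(F)F)cc3c2=O)cc1` has not yet been measured in this assay. Its difference from compound 3: trifluoromethyl in place of fluoro on an aromatic carbon. Among the measured compounds shown here, no pair of measured compounds shows this exchange, so the size of the step has no precedent; the rest of the shared core is unchanged, and only the substituent on the fused ring is swapped. The step is expected to stay within the scatter, a 1.2-fold higher number from compound 3 to compound 4 (0.09 log units; within the scatter), with no clear direction. Compound 4 is estimated at 220 nM in this assay, within a range from 80 nM to 600 nM, a range that reflects the absence of any measured precedent for this change.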

Compound 4, half-maximal inhibitory concentration: 584 nM
Compound 4: the middle estimate sits 2.7-fold (0.42 log units) below what was measured; the measured number falls inside the stated range.
By their numbers in this assay, from the lowest: compound 3; then compounds 2, 4 and 1 (each within the scatter of the next).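

In this assay, among the compounds shown here, the aromatic carbon of the fused system does not tolerate every substituent equally: trifluoromethyl in place of fluoro gives a 3.3-fold higher number from compound 3 to compound 4 (0.52 log units; beyond the scatter) and is the first single-place exchange to give a readable step. The step is modest but lies beyond the scatter, so this carbon is a place where a substituent change can shift the number while the rest of the shared core stays fixed. The entering group carries four heavy atoms where the leaving group carries one, but nothing shown gives a reason for the step.

The compounds shown leave open where a plain hydrogen on this carbon would fall, so it cannot yet be said whether fluoro lowers the number or trifluoromethyl raises it. Also open, from the compounds shown here alone, are how chloro, methyl or methoxy on the same carbon would compare, and whether the same exchange would give a similar step on the different linkers of compound 1 and compound 2.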